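A few compounds are considered here, and "the series" means these few. Any claim that something is new, unique, unknown or untested is made for them only; others in the source may bear on it.

In an ADME assay on NHDF cells (Homo sapiens) for cytotoxicity, read by MTT assay, with a stated time of 72 h (a higher number here means a weaker inhibitor, a lower number a stronger inhibitor), compound 1 `COc1cccc(/C=C2\CCC/C(=C\c3cccc(O)c3)C2=O)c1OC` gives 19300 nM and compound 2 `COc1cccc(/C=C2\CCC/C(=C\c3ccc(Cl)c(Cl)c3)C2=O)c1OC` gives 25500 nM, so these two compounds cannot be told apart beyond the usual scatter of repeat measurements. Compound 3 `COc1cc(/C=C2\CCC/C(=C\c3cccc(OC)c3OC)C2=O)ccc1O` has not yet been measured. It differs from compound 2 at a single place, on a double-bonded chain carbon bound to a double-bonded ring carbon: 4-hydroxy-3-methoxyphenyl in place of 3,4-dichlorophenyl on a double-bonded chain carbon bound to a double-bonded ring carbon. Going by the values given here, only one measured step changes a group at that same place, replacing 3-hydroxyphenyl with 3,4-dichlorophenyl. That step is a 1.3-fold higher number from compound 1 to compound 2 (0.12 log units; within the scatter). Among the compounds with values here, one small step is thin evidence, and no measured compound yet carries the incoming 4-hydroxy-3-methoxyphenyl group. With that single step as the guide, no change beyond the scatter is expected in this assay. The estimated step is a 1.3-fold lower number from compound 2 to compound 3 (0.11 log units; within the scatter). For compound 3 the expected value is 20000 nM, with an estimated range of 9000 nM to 42000 nM.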

Compound 3, half-maximal inhibitory concentration: 14300 nM
Compound 3: the middle estimate sits 1.4-fold (0.15 log units) above what was measured, within the range that was stated.
By their numbers in this assay, from the lowest: compounds 3, 1 and 2 (each within the scatter of the next).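

In this assay, going by these compounds alone, the position on a double-bonded chain carbon bound to a double-bonded ring carbon now carries three different groups, where the earlier compounds offered only one swap. Both a 1.8-fold lower number from compound 2 to compound 3 (0.25 log units; within the scatter) and a 1.3-fold lower number from compound 1 to compound 3 (0.13 log units; within the scatter) stay small enough that 3-hydroxyphenyl, 3,4-dichlorophenyl and 4-hydroxy-3-methoxyphenyl cannot be told apart here, even though the change from 3,4-dichlorophenyl brings in hydrogen-bond donor and acceptor counts where there were none. Nothing available explains why these groups read alike.

All three groups are substituted phenyl rings, so this tolerance is shown for those three alone. From the compounds shown here alone, whether an amine or a carboxylic acid on that ring, or a longer chain in place of it, would shift the number beyond the scatter remains open.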